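Hydroxyethyl Ester Replaces Glycine Methyl Ester Amide

The source may report more compounds than this note shows. Statements on the series, on what has been measured and on what is new or still open speak of the compounds shown alone.

Measured compounds:
- compound 1 `CCN(CC)CCCNC(=O)c1ccc(C(CC)(CC)c2ccc(C#CC(O)(CC)CC)c(C)c2)n1CC`: 68.9 nM
- compound 2 `CCn1c(C(=O)NCCC(=O)O)ccc1C(CC)(CC)c1ccc(C#CC(O)(CC)CC)c(C)c1`: 293 nM
- compound 3 `CCn1cc(C(CC)(CC)c2ccc(C#CC(O)(CC)CC)c(C)c2)cc1C(=O)NCC(=O)OC`: 288 nM

Of the compounds shown here, three sharing one core have been measured in an assay on cells for agonist activity at vitamin D3 receptor (Homo sapiens), read by microscopy; a higher number here means that more compound is needed for the effect, a lower number that less compound is needed. Compound 1 gives 68.9 nM, the lowest number of the three. Compound 2 gives 293 nM, and compound 3 gives 288 nM; these two stand within the scatter of each other, so nothing separates them. Compound 3 therefore sits with compound 2 at the higher end, well apart from compound 1.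

The next compound, compound 4 `CCn1cc(C(CC)(CC)c2ccc(C#CC(O)(CC)CC)c(C)c2)cc1C(=O)OCCO`, has not yet been measured. It differs from compound 3 in one place: 2-hydroxyethoxy in place of ((methoxycarbonyl)methyl)amino on a carbonyl carbon.

Among the measured compounds shown here, only one step between measured compounds has been characterised, a 4.3-fold higher number from compound 1 to compound 2 (0.63 log units; beyond the scatter). That step changes the tail on the amide side chain and does not touch the carbonyl itself, so it bears only loosely on the change from compound 3 to compound 4. What the measured compounds show is that swapping the group beyond the carbonyl between a neutral ester and an acid, as between compound 2 and compound 3, left the number essentially unchanged. The expectation for compound 4 is therefore a step of a 1.4-fold higher number from compound 3 to compound 4 (0.14 log units; within the scatter), within or near the scatter. Compound 4 is estimated at 400 nM, with a range from 150 nM to 1200 nM.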

Compound 4, half-maximal effective concentration: 12.6 nM
Beside the measured number, compound 4's estimate is 32-fold (1.50 log units) above it; the measured number lies below the stated range.
By their numbers in this assay, from the lowest: compound 4; then compound 1; then compounds 3 and 2 (each within the scatter of the next).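

In this assay, the group on the carbonyl carbon turns out to have a large effect on the number: 2-hydroxyethoxy in place of ((methoxycarbonyl)methyl)amino gives a 23-fold lower number from compound 3 to compound 4 (1.36 log units; beyond the scatter), a bigger step than the only earlier one, a 4.3-fold higher number from compound 1 to compound 2 (0.63 log units; beyond the scatter). That earlier step altered only the end of an amide side chain. Among the compounds shown here, the new step is the only one here with a change made directly on the carbonyl carbon, and it comes with the same counts of hydrogen-bond donors and acceptors on both sides, so those counts do not separate the two groups. Nothing measured here accounts for the size of the step.

The change swaps the amide nitrogen for an ester oxygen, shortens the group and replaces the methyl ester end with a hydroxyl, and the compounds shown leave open which of these carries the step; a 2-hydroxyethyl amide and a plain ethyl ester would pull them apart. Also open, going by these compounds, is whether a longer chain such as 3-hydroxypropoxy, or an amine in place of the terminal hydroxyl, would keep the number as low.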